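The compounds below may be only part of what the source reports. "The series", "measured", "known", "first", "only" and "open" are said of these compounds alone.

Measured compounds in a functional assay on OVCAR-3 cells (Homo sapiens) for inhibition; a lower number here means a stronger inhibitor of growth, a higher number a weaker inhibitor of growth:
compound 1 `COc1cc(/C=C/C(=O)c2cccc(-n3cc(-c4ccc(Cl)cc4)[nH]c3=O)c2)cc(OC)c1OC` gives 2400 nM
compound 2 `COc1cc(/C=C/C(=O)c2cccc(-n3cc(-c4ccccc4)[nH]c3=O)c2)ccc1O` gives 2290 nM
compound 3 `COc1ccc(-c2cn(-c3cccc(C(=O)/C=C/c4ccc(O)c(OC)c4)c3)c(=O)[nH]2)cc1` gives 2700 nM

Compound 1 stands second highest of the three numbers; its nearest neighbour is compound 2, and the furthest is compound 3, and both gaps are within the scatter, so the three measured compounds cannot be ordered against each other on this assay.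

The unmeasured compound 4 `COc1cc(/C=C/C(=O)c2cccc(-n3cc(-c4cc(OC)c(OC)c(OC)c4)[nH]c3=O)c2)cc(OC)c1OC` differs from compound 1 in one place: 3,4,5-trimethoxyphenyl in place of 4-chlorophenyl on an aromatic carbon. Within the data shown here, the only measured step that bears on the group attached to the five-membered ring is the one from compound 2 to compound 3, where a methoxy enters on that aromatic ring: a 1.2-fold higher number from compound 2 to compound 3 (0.07 log units; within the scatter). Among the measured compounds shown here, that step is smaller than the change to compound 4, which swaps the chlorine for three methoxy groups, but it is the only guide available, and it shows no movement beyond the scatter. The change from compound 1 to compound 4 is therefore expected to give no step beyond the scatter, with the direction undecided.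

Compound 4 is estimated at 2500 nM in this assay, between 900 nM and 7000 nM, which is expected to correspond to a step of a 1.0-fold higher number from compound 1 to compound 4 (0.02 log units; within the scatter).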

Compound 4, concentration for 50% growth inhibition: 1480 nM
Compound 4: middle estimate off by 1.7-fold (0.23 log units), on the high side; the measured number falls inside the stated range.
By their numbers in this assay, from the lowest: compounds 4, 2, 1 and 3 (each within the scatter of the next).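

In this assay, among these compounds, a 1.6-fold lower number from compound 1 to compound 4 (0.21 log units; within the scatter) gives the first reading of a whole-group exchange on the aromatic carbon of the five-membered aromatic ring with 2 nitrogen; the earlier step changed only one substituent on the attached ring. 4-Chlorophenyl, with 7 heavy atoms and 0 hydrogen-bond acceptors, gives way to 3,4,5-trimethoxyphenyl, with 12 heavy atoms and 3 hydrogen-bond acceptors, and the number still stays within the scatter, so this position accepts both groups with the rest of the structure held fixed. No measurement shown here bears on why the step stays this small.

All the groups shown at this position are aromatic rings with no net charge, so it remains open whether an amine or a carboxylic acid on that ring, or a small alkyl group such as methyl in its place, would give a step beyond the scatter. As far as these compounds go, it also remains open whether the same exchange of 4-chlorophenyl for 3,4,5-trimethoxyphenyl would read alike on the core of compound 2.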